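Phenyl for Ethyl on the Urea Nitrogen

The source may report more compounds than this note shows. Statements on the series, on what has been measured and on what is new or still open speak of the compounds shown alone.

Of the compounds shown here, two have been measured in an assay for inhibition of Nitric oxide synthase, inducible (Homo sapiens), read by scintillation counting, with a stated time of 30 min, tested at 1 mM; a lower number here means less inhibition, a higher number more inhibition at the concentration tested (going by the name of the read-out). Compound 1 `Nc1ccccc1C(O)CCNC(=O)Nc1ccccc1` gives 27.9%. Compound 2 `CCNC(=O)NCCC(O)c1cc(Cl)ccc1N` gives 33.9%, the higher of the two numbers, though its gap to compound 1 lies within the scatter. Compound 3 `Nc1ccc(Cl)cc1C(O)CCNC(=O)Nc1ccccc1` has not been measured; it differs from compound 2 by phenyl in place of ethyl on an amide-type nitrogen. Compound 1 already carries this phenyl and gives 27.9%, so no step beyond the scatter is expected. The estimated step from a number 3.9 percentage points lower from compound 2 to compound 3 (within the scatter) is small. Compound 3 is therefore expected to give about 30%, between 18% and 42%.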

Compound 3, a percentage reported as inhibition, at one concentration (the size of the read-out at that concentration, not a potency): 3.11%
Compound 3: the middle estimate sits 26.9 percentage points above what was measured, and the stated range ends above it.
By their numbers in this assay, from the lowest: compound 3; then compounds 1 and 2 (each within the scatter of the next).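

In this assay, phenyl in place of ethyl on the amide-type nitrogen gives a number 30.8 percentage points lower from compound 2 to compound 3 (beyond the scatter), and chloro in place of hydrogen on the aromatic carbon gives a number 24.8 percentage points lower from compound 1 to compound 3 (beyond the scatter). Each change therefore matters in the presence of the other group, and the low number belongs only to compound 3, the one compound shown that carries both phenyl and chloro. Nothing available explains this drop. Still open, from the compounds shown here alone, is whether benzyl on that nitrogen, or fluoro or methyl in place of chloro, would follow compound 2 or compound 3.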